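Urea-bearing analogue replaces an ester-bearing side chain

A few compounds are considered here, and "the series" means these few. Any claim that something is new, unique, unknown or untested is made for them only; others in the source may bear on it.

The series shares one core, carried by compound 1 `CCN(CC)CCNC(=O)Nc1nc2ccc(-c3cnc(OC)c(NS(=O)(=O)c4ccc(F)cc4)c3)cc2s1`, compound 2 `CNC(=O)Nc1nc2ccc(-c3cnc(OC)c(NS(=O)(=O)c4ccc(F)cc4)c3)cc2s1` and compound 3 `CCOC(=O)CNc1nc2ccc(-c3cnc(OC)c(NS(=O)(=O)c4ccc(F)cc4)c3)cc2s1`. In a functional assay on MCF7 cells (Homo sapiens) for antiproliferative activity, read by MTT assay, with a stated time of 72 h (on this read-out lower numbers stand for stronger inhibition and higher numbers for weaker inhibition), compound 1 gives 320 nM, and in this assay compound 2 gives 1190 nM. In this assay compound 3 gives "not determined" (no result reported), so compound 3 stands nowhere on the numbers; it can only be placed by its structure, which carries an (ethoxycarbonyl)methyl group where compound 1 and compound 2 carry urea groups.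

Compound 4 `COc1ncc(-c2ccc3nc(NC(=O)NCCN4CCN(C)CC4)sc3c2)cc1NS(=O)(=O)c1ccc(F)cc1` is not yet measured. Compared with compound 3 it shows ((2-(4-methylpiperazin-1-yl)ethyl)carbamoyl in place of (ethoxycarbonyl)methyl on a nitrogen on an aromatic ring). The group that enters makes compound 4 a urea closely resembling compound 1, which also bears a urea with an amine-containing chain, whereas compound 2 carries only a methyl on its urea. For the measured compounds named here, the one measured step that bears on this, a 3.7-fold higher number from compound 1 to compound 2 (0.57 log units; beyond the scatter), shows that the chain on the urea matters, with compound 1 giving the lower number. Compound 4 is therefore expected to sit near compound 1 rather than compound 2, with the absence of any measurement for compound 3 leaving the size of the step itself open. Compound 4 is estimated at 350 nM, with a range from 120 nM to 1000 nM.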

Compound 4, half-maximal inhibitory concentration: 470 nM
Estimate against measurement, compound 4: 1.3-fold (0.13 log units) below, within the range that was stated.
By their numbers in this assay, from the lowest: compounds 1 and 4 (each within the scatter of the next); then compound 2.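

Compound 4 shows that this urea nitrogen carries a second chain ending in a ring amine as well as it carries the open diethylamino chain: in this assay, 4-methylpiperazin-1-yl in place of diethylamino on a saturated chain carbon, two bonds along the chain from an amide-type nitrogen, gives a 1.5-fold higher number from compound 1 to compound 4 (0.17 log units; within the scatter) and so separates compound 1 and compound 4 by no real margin. For the compounds shown here, the earlier pair had offered only one comparison with the methyl urea, whereas (4-methylpiperazin-1-yl)methyl in place of hydrogen on a saturated chain carbon bound to an amide-type nitrogen now gives a 2.5-fold lower number from compound 2 to compound 4 (0.40 log units; beyond the scatter), so two different chain ends both stand apart from compound 2 in the same direction. Nothing shown accounts for these differences.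

On these data alone, how a chain ending in a hydroxyl group or a carboxylic acid, or a longer chain before the amine, would compare remains open. The step from compound 3 to compound 4 cannot be read, so the urea cannot be set against the (ethoxycarbonyl)methyl group on the numbers.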